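The source may hold more compounds than are shown below. What is called first, only, known or untested is meant among the compounds shown, and "the series" means these compounds.

Compound 1 `O=C(CCCCCC(=O)Nc1nnc(-c2cccs2)s1)NO` is the weaker of the two measured compounds in a functional assay on MDA-MB-231 cells (Homo sapiens) for antiproliferative activity, read by MTT assay, with a stated time of 48 h; on this read-out higher numbers stand for weaker inhibition and lower numbers for stronger inhibition: compound 1 gives 15200 nM, while compound 2 `O=C(CCCCCC(=O)Nc1nnc(-c2cccnc2)s1)NO` gives 11700 nM. Among the compounds with values here, the only measured step, a 1.3-fold lower number from compound 1 to compound 2 (0.11 log units; within the scatter), swaps the aromatic group and so does not bear on compound 3 `O=C(CCCCCCC(=O)Nc1nnc(-c2cccs2)s1)NO`, which differs from compound 1 by (hydroxycarbamoyl)methyl in place of hydroxycarbamoyl on a saturated chain carbon, five bonds along the chain from a carbonyl carbon. Within the data shown here, with no measured step touching the chain, a change in this assay beyond the scatter is not expected, and compound 3 is estimated at 13000 nM, within 6000 nM to 30000 nM, an expected step of a 1.2-fold lower number from compound 1 to compound 3 (0.07 log units; within the scatter).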

Compound 3, half-maximal inhibitory concentration: 1210 nM
Compound 3: middle estimate off by 11-fold (1.03 log units), on the high side, and the stated range ends above it.
By their numbers in this assay, from the lowest: compound 3; then compounds 2 and 1 (each within the scatter of the next).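

In this assay the saturated chain proves far more responsive than the aromatic group: (hydroxycarbamoyl)methyl in place of hydroxycarbamoyl gives a 13-fold lower number from compound 1 to compound 3 (1.10 log units; beyond the scatter) and so goes well beyond the scatter. The aromatic change, by contrast, gives only a 1.3-fold lower number from compound 1 to compound 2 (0.11 log units; within the scatter) and stays within it. Nothing available here accounts for the size of the chain step.

Going by these compounds, whether 2-(hydroxycarbamoyl)ethyl at this place would lower the number further or raise it again remains open. Also open, on these data alone, are how a carboxylic acid would fare in place of the hydroxycarbamoyl end, and whether pyridin-3-yl behaves as thiophen-2-yl does on the longer chain.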